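The source may hold more compounds than are shown below. What is called first, only, known or untested is meant among the compounds shown, and "the series" means these compounds.

Measured so far in a functional assay with Homo sapiens as the target; on this read-out lower numbers stand for stronger inhibition and higher numbers for weaker inhibition:
- Compound 1 `CC(C)[C@H](NC(=O)COc1cccc2ccccc12)C(=O)N[C@@H](CC(=O)O)C(=O)COc1ccc(C#N)cc1`: 26700 nM
- Compound 2 `CC(C)[C@H](NC(=O)COc1cccc2ccccc12)C(=O)N[C@@H](CC(=O)O)C(=O)COc1ccc(F)c(F)c1`: 16200 nM

Compound 2, at 16200 nM, lies within the usual scatter of compound 1, so the two cannot be told apart on these numbers. The next structure, compound 3 `CC(C)[C@H](NC(=O)COc1cccc2ccccc12)C(=O)N[C@@H](CC(=O)O)C(=O)COc1cc(F)cc(F)c1F`, alters the same group on the oxygen: 2,3,5-trifluorophenyl in place of 3,4-difluorophenyl on an oxygen on a saturated carbon. Among the measured compounds shown here, only one measured step bears on this, a 1.6-fold lower number from compound 1 to compound 2 (0.22 log units; within the scatter), which put 3,4-difluorophenyl in place of 4-cyanophenyl at that same place. A single step is thin evidence, but that swap did not move the number beyond the scatter, so a similar outcome seems the fair expectation in this assay. The expected size is a 1.1-fold lower number from compound 2 to compound 3 (0.03 log units; within the scatter), with no firm direction expected. For compound 3 the estimated value is 15000 nM, with an expected range from 6000 nM to 40000 nM.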

Compound 3, half-maximal inhibitory concentration: 11200 nM
Estimate against measurement, compound 3: 1.3-fold (0.13 log units) above, and the stated range covers the measured number.
By their numbers in this assay, from the lowest: compounds 3, 2 and 1 (each within the scatter of the next, the first and the last beyond it).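

In this assay, exchanging 3,4-difluorophenyl for 2,3,5-trifluorophenyl on the oxygen gives a 1.4-fold lower number from compound 2 to compound 3 (0.16 log units; within the scatter) and so leaves compound 2 and compound 3 indistinguishable. Comparing the same 2,3,5-trifluorophenyl group with 4-cyanophenyl gives a 2.4-fold lower number from compound 1 to compound 3 (0.38 log units; beyond the scatter) and is the first step at this place to clear the scatter, though only modestly. No supporting measurement is available to explain this difference.

Among the compounds shown here, with only one group carrying three fluorines, these compounds cannot separate the effect of the number of fluorines from that of their arrangement on the ring. Also open, as far as these compounds go, is what a plain phenyl ring, an aminophenyl group or a simple saturated chain such as hexyl would do on this oxygen.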